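The compounds below may be only part of what the source reports. "The series", "measured", "known", "first", "only" and "open" are said of these compounds alone.

In a functional assay on A-375 cells (Homo sapiens) for antiproliferative activity, read by MTT assay, with a stated time of 24 h (on this read-out lower numbers stand for stronger inhibition and higher numbers for weaker inhibition), compound 3 `COc1cc(OC)c(-c2coc3cc(OCc4ccccc4C(F)(F)F)ccc3c2=O)cc1OC` gives > 10000 nM, which is a limit of the assay and not a number. Compound 1 `COc1cccc(C(=O)Oc2ccc3c(=O)c(-c4cc(OC)c(OC)cc4OC)coc3c2)c1` gives > 10000 nM, which is also a limit. Compound 2 `COc1cc(OC)c(-c2coc3cc(OCc4ccccc4C)ccc3c2=O)cc1OC` gives a true number, 1360 nM. Compound 1 and compound 3 both carry limits, so no size can be read between them.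

Compound 4 `COc1cc(OC)c(-c2coc3cc(OCc4ccccc4Br)ccc3c2=O)cc1OC` has not yet been measured. It has bromo in place of trifluoromethyl on an aromatic carbon, ortho to a large group: bromo in place of trifluoromethyl on an aromatic carbon.

The most relevant measured change is at this same carbon, where trifluoromethyl replaces methyl: an at least 7.3-fold higher number from compound 2 to compound 3 (0.86 log units; beyond the scatter). The step of an at least 7.3-fold lower number from compound 1 to compound 2 (0.86 log units; beyond the scatter) shows that a benzyl compound can give a measurable number here. Only methyl and trifluoromethyl have been tested at this carbon, so the direction for bromo is uncertain, and compound 4 could also stop at the limit.

A modest move to a lower number is expected, read as an at least 2.8-fold lower number from compound 3 to compound 4 (0.45 log units; beyond the scatter). For compound 4 the estimate is 3500 nM, with an expected range of 1000 nM to 10000 nM.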

Compound 4, half-maximal inhibitory concentration: 2850 nM
For compound 4 the middle estimate is 1.2-fold (0.09 log units) above the measured one, and the stated range covers the measured number.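

In this assay, bromo on this aromatic carbon gives an at least 3.5-fold lower number from compound 3 to compound 4 (0.54 log units; beyond the scatter), so a true number returns where trifluoromethyl reached only a limit of the assay. Methyl still gives the lowest number of the three groups at this carbon, with a 2.1-fold higher number from compound 2 to compound 4 (0.32 log units; beyond the scatter). Putting 2-bromobenzyl in place of (3-methoxyphenyl)carbonyl gives an at least 3.5-fold lower number from compound 1 to compound 4 (0.54 log units; beyond the scatter), which makes it the second benzyl group after 2-methylbenzyl to give a true number, while 2-(trifluoromethyl)benzyl goes against this pattern.

From the compounds shown here alone, the full size of the two steps that start from a limit stays open, because each gives only a smallest possible size when one end sits at that limit: the limit of > 10000 nM in this assay, at which 2 of the 4 values shown sit. Whether chloro, an amine or a carboxylic acid at this carbon would give a lower number than methyl also remains open.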